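Fluoro for hydrogen on the shared core: working notes

A few compounds are considered here, and "the series" means these few. Any claim that something is new, unique, unknown or untested is made for them only; others in the source may bear on it.

Measured so far:
compound 1 `N[C@@H]1CCN(c2cc3c(cc2F)c(=O)c(C(=O)O)cn3Cc2ccc(-c3ccccc3)cc2)C1` gives 63600 nM
compound 2 `NC[C@@H]1CCN(c2ccc3c(=O)c(C(=O)O)cn(Cc4ccc(-n5cccn5)cc4)c3c2)C1` gives 61000 nM
compound 3 `NC[C@@H]1CCN(c2ccc3c(=O)c(C(=O)O)cn(Cc4ccc(-c5ccccc5)cc4)c3c2)C1` gives 61200 nM

In an assay on isolated protein for inhibition of DNA topoisomerase 1 (Homo sapiens), with a stated time of 15 min (a higher number here means a weaker inhibitor, a lower number a stronger inhibitor), the three measured compounds sit together. Compound 2 holds the lowest of the three numbers, but both neighbours lie within the scatter of it. Compound 4 `NC[C@@H]1CCN(c2cc3c(cc2F)c(=O)c(C(=O)O)cn3Cc2ccc(-n3cccn3)cc2)C1` differs from compound 2 by fluoro in place of hydrogen on an aromatic carbon. Among the compounds with values here, the one measured single change, a 1.0-fold higher number from compound 2 to compound 3 (0.00 log units; within the scatter), concerns another place and gives no guidance on a fluoro for hydrogen swap. Within the data shown here, compound 1 carries a fluoro at the same place yet differs from compound 2 elsewhere as well, so its value shows only that such a member sits in the same range. Compound 4 is therefore expected to show no step beyond the scatter, a 1.0-fold lower number from compound 2 to compound 4 (0.01 log units; within the scatter). Compound 4 is estimated at 60000 nM, between 25000 nM and 150000 nM.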

Compound 4, half-maximal inhibitory concentration: 91600 nM
Compound 4: the middle estimate sits 1.5-fold (0.18 log units) below what was measured; measured number inside the range.
By their numbers in this assay, from the lowest: compounds 2, 3, 1 and 4 (each within the scatter of the next).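

In this assay, within the data shown here, fluoro in place of hydrogen on the aromatic carbon ortho to the 3-(aminomethyl)pyrrolidin-1-yl group gives a 1.5-fold higher number from compound 2 to compound 4 (0.18 log units; within the scatter) and is the only direct reading of this change on the shared core. With this side chain and the 1H-pyrazol-1-yl group in place, the swap at this position stays within the scatter. No data at hand speak to what lies behind this step.

Still open, on these data alone, is whether chloro, methoxy or nitrile on the same aromatic carbon would move the number beyond the scatter. The fluoro swap also remains unread with phenyl in place of 1H-pyrazol-1-yl.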